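Branched side chains on the amide-bearing carbon of the series

A few compounds are considered here, and "the series" means these few. Any claim that something is new, unique, unknown or untested is made for them only; others in the source may bear on it.

The three measured compounds share one core. Compound 1 `CC(=O)c1ccc(NC(=O)C(C(C)C)N(C(=O)c2ccccc2)S(=O)(=O)c2ccc(C)cc2)cc1` gives 42.7% in a functional assay for inhibition, read by spectrophotometry, with a stated time of 20 min, tested at 5 mg/mL; a lower number here means a weaker effect, a higher number a stronger effect of the compound at the concentration tested. Compound 2 `CC(=O)c1ccc(NC(=O)CN(C(=O)c2ccccc2)S(=O)(=O)c2ccccc2)cc1` gives 45.4% in this assay, and compound 3 `CC(=O)c1ccc(NC(=O)C(CC(C)C)N(C(=O)c2ccccc2)S(=O)(=O)c2ccccc2)cc1` gives 52.2%. On these numbers compound 3 holds the highest value of the three, but its distance to compound 2 and to compound 1 is within the scatter in both cases, so no order among them can be read.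

The unmeasured compound 4 `CC(=O)c1ccc(NC(=O)C(C(C)C)N(C(=O)c2ccccc2)S(=O)(=O)c2ccccc2)cc1` differs from compound 3 in one place: isopropyl in place of isobutyl on a saturated chain carbon bound to an amide-type nitrogen and a carbonyl carbon. Among the measured compounds shown here, the one measured step at that place, a number 6.8 percentage points higher from compound 2 to compound 3 (within the scatter), stayed within the scatter. For the measured compounds named here, compound 1 carries the same isopropyl group at the same place but differs from compound 4 elsewhere, so no step is drawn from it. In this assay compound 1 gives 42.7%, which simply sits in the same band as the other two.

Given that the only relevant step, a number 6.8 percentage points higher from compound 2 to compound 3 (within the scatter), did not leave the scatter, no step beyond the scatter is expected from compound 3 to compound 4; the expected step is a number 7.2 percentage points lower from compound 3 to compound 4 (within the scatter). For compound 4 in this assay the estimate is 45%, expected within the range 35% to 55%.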

Compound 4, a percentage reported as inhibition, at one concentration (the size of the read-out at that concentration, not a potency): 54.2%
The estimate for compound 4 lay 9.2 percentage points below the measured number, within the range that was stated.
By their numbers in this assay, from the lowest: compounds 1, 2, 3 and 4 (each within the scatter of the next, the first and the last beyond it).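

Among the compounds shown here, at the saturated chain carbon bound to an amide-type nitrogen and a carbonyl carbon, isopropyl in place of isobutyl gives a number 2 percentage points higher from compound 3 to compound 4 (within the scatter) in this assay, and isopropyl in place of hydrogen gives a number 8.8 percentage points higher from compound 2 to compound 4 (within the scatter), so across hydrogen, isobutyl and isopropyl this position shows no step that leaves the scatter. For the compounds shown here, the new information comes from another place: hydrogen in place of methyl on an aromatic carbon gives a number 11.5 percentage points higher from compound 1 to compound 4 (beyond the scatter), the first step to leave the scatter, though it is modest and rests on this single pair. Nothing available accounts for either the flat chain position or the aromatic step.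

The compounds shown carry only hydrogen, isopropyl and isobutyl at the chain carbon, so it remains open whether an amine, a carboxylic acid or a longer chain there would move the read-out beyond the scatter. Also open is whether the aromatic step recurs with hydrogen or isobutyl at the chain carbon, and how any of these compounds would behave at other concentrations.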